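A few compounds are considered here, and "the series" means these few. Any claim that something is new, unique, unknown or untested is made for them only; others in the source may bear on it.

In an ADME assay on HepG2 2.2.15 cells (Homo sapiens) for cytotoxicity (on this read-out lower numbers stand for higher toxicity in this test and higher numbers for lower toxicity in this test), compound 1, `O=C(Nc1ncc(Cc2ccc(F)cc2)s1)c1ccc(Br)cc1`, reaches only the assay limit of > 50000 nM, which is a limit and not a number. Compound 2, `CC(C)(C)OC(=O)Nc1ncc(C(Oc2ccc(OCc3ccccc3)cc2)c2ccc(Cl)cc2)s1`, likewise gives just the limit of > 50000 nM in this assay. Compound 3, `COCCNc1ncc(C(Oc2ccc3cc(Br)ccc3c2)c2ccc(Cl)cc2)s1`, is reported in this assay as "not toxic" (no number reported), without a figure, so it stands with the other two, beside the evidence that (the limit of > 50000 nM in this assay, at which 2 of the 3 values shown sit). Compound 4, `O=C(Nc1ncc(C(Oc2ccc3cc(Br)ccc3c2)c2ccc(Cl)cc2)s1)c1ccc(F)cc1F`, carries (2,4-difluorophenyl)carbonyl in place of 2-methoxyethyl on a nitrogen on an aromatic ring. For the measured compounds named here, with no step between measured compounds to go by, the expectation for compound 4 in this assay is a result of the same kind, not beyond the scatter: an estimate of 50000 nM, within 20000 nM to 100000 nM, most likely again only a limit.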

Compound 4, half-maximal cytotoxic concentration: "not toxic" (no number reported)
The entry for compound 4 holds no number; the estimate stays without a comparison.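

In this assay compound 3 and compound 4 both carry no number, so no step can be read between them. On these data alone, what stays open is whether exchanging 2-methoxyethyl for (2,4-difluorophenyl)carbonyl shifts the half-maximal cytotoxic concentration at all.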